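The source may report more compounds than this note shows. Statements on the series, on what has been measured and on what is new or still open speak of the compounds shown alone.

Working notes on the series

Three compounds carry a number in a functional assay on CHO cells for agonist activity at Alpha-1A adrenergic receptor (Homo sapiens), read by FLIPR and calcium flux; on this read-out higher numbers stand for an effect only at larger amounts of compound and lower numbers for an effect already at smaller amounts. Compound 1 `c1ccc(-c2cccc3c2CCC3c2ncc[nH]2)nc1` gives 1150 nM in this assay, the highest of the three numbers. Compound 3 `c1ccc2c(c1)CCCC2c1ncc[nH]1` sits nearest to it and gives 385 nM, a lower number, with the gap beyond the scatter. Compound 2 `CCS(=O)(=O)Nc1cccc(Cc2c[nH]cn2)c1`, built on a different core, lies furthest from compound 1. In this assay compound 2 gives 9 nM, a gap also beyond the scatter. Compound 1 therefore stands at the weak end of what has been measured so far.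

Compound 4 `COc1cccc2c1CCC2c1ncc[nH]1` has not yet been measured in this assay. It differs from compound 1 in one place: methoxy in place of pyridin-2-yl on an aromatic carbon. Going by the values given here, no measured pair shows this exact change, so any expectation must rest on the three numbers above. Compound 3 shows that a core without the pyridin-2-yl can give a lower number, so a moderate move toward lower numbers is expected, with the step from compound 1 to compound 4 estimated as a 2.6-fold lower number from compound 1 to compound 4 (0.41 log units; beyond the scatter), though it may well stay within the scatter. Compound 4 is expected to give about 450 nM in this assay, within a range from 120 nM to 1800 nM.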

Compound 4, half-maximal effective concentration: 32 nM
Beside the measured number, compound 4's estimate is 14-fold (1.15 log units) above it; measured number below the stated range.
By their numbers in this assay, from the lowest: compound 2; then compound 4; then compound 3; then compound 1.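

At this aromatic carbon, ortho to a fused ring and meta to a fused ring, the group carried has a large bearing on the read-out: methoxy in place of pyridin-2-yl gives a 36-fold lower number from compound 1 to compound 4 (1.56 log units; beyond the scatter) in this assay. Going by these compounds alone, this is the first step that changes one place alone, and it shows that a ring is not needed at this carbon for a low number. The two groups have the same counts of hydrogen-bond donors and acceptors, so the step goes with the difference in heavy atoms and the loss of the ring, not with those counts.

No evidence on hand explains the step. The compounds shown leave open whether the oxygen of methoxy matters or whether a chlorine or an ethoxy group at this carbon would give a similar number.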